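This account rests on a few compounds, and the source may have more. Where it says the series, first, only, none or still open, it means among the compounds named here.

In a functional assay on HL-60 cells (Homo sapiens) for antiproliferative activity, with a stated time of 72 h; a higher number here means a weaker inhibitor, a lower number a stronger inhibitor:
- compound 1 `OC[C@H]1O[C@@H](n2cnc3c(NCc4cccc(F)c4)ncnc32)[C@H](O)[C@@H]1O`: 920 nM
- compound 2 `OC[C@H]1O[C@@H](n2cnc3c(NCc4ccccc4Cl)ncnc32)[C@H](O)[C@@H]1O`: 1600 nM
- compound 3 `Cc1cccc(CNc2ncnc3c2ncn3[C@@H]2O[C@H](CO)[C@@H](O)[C@H]2O)c1`: 6400 nM

Compound 3 has the highest number of the three. The next structure, compound 4 `OC[C@H]1O[C@@H](n2cnc3c(NCc4ccc(Cl)c(Cl)c4)ncnc32)[C@H](O)[C@@H]1O`, carries 3,4-dichlorophenyl in place of 3-methylphenyl on a saturated chain carbon bound to a nitrogen on an aromatic ring.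

Going by the values given here, two measured steps bear on this, both going from a halogen-bearing compound to the methyl compound: a 7.0-fold higher number from compound 1 to compound 3 (0.84 log units; beyond the scatter) and a 4.0-fold higher number from compound 2 to compound 3 (0.60 log units; beyond the scatter). Between the two halogen-bearing compounds, the data show a 1.7-fold higher number from compound 1 to compound 2 (0.24 log units; within the scatter). Among the compounds with values here, no measured compound carries two chlorines, so the reading is uncertain.

A modest move to a lower number is expected, an estimated 4.3-fold lower number from compound 3 to compound 4 (0.63 log units; beyond the scatter). The estimate for compound 4 is 1500 nM, with an expected range of 500 nM to 4500 nM.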

Compound 4, half-maximal inhibitory concentration: 2000 nM
Compound 4: the middle estimate sits 1.3-fold (0.12 log units) below what was measured; the range from low to high includes it.
By their numbers in this assay, from the lowest: compounds 1, 2 and 4 (each within the scatter of the next, the first and the last beyond it); then compound 3.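

Replacing 3-methylbenzyl with 3,4-dichlorobenzyl gives a 3.2-fold lower number from compound 3 to compound 4 (0.51 log units; beyond the scatter) and shows that two chlorines are accepted at this position, with all three halogen-bearing compounds now showing lower numbers than compound 3. The second comparison, a 1.3-fold higher number from compound 2 to compound 4 (0.10 log units; within the scatter), shows no separation from the single-chlorine group, so the added chlorine brings no measurable gain. The third, a 2.2-fold higher number from compound 1 to compound 4 (0.34 log units; beyond the scatter), leaves 3,4-dichlorobenzyl short of 3-fluorobenzyl, and no measurement offers an explanation for these differences.

As far as these compounds go, how each chlorine of compound 4 acts alone remains open. Also open, from the compounds shown here alone, is whether an amine or methoxy on the aromatic ring, or a longer chain in place of the benzyl group, would keep this activity.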